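Halogenated benzyl variation on a sulfonamide-linked indole series

The source may report more compounds than this note shows. Statements on the series, on what has been measured and on what is new or still open speak of the compounds shown alone.

Of the compounds shown here, three have been measured in a functional assay on 3T3-L1 cells (Mus musculus) for inhibition, with a stated time of 20 min, tested at 20 uM; a higher number here means more inhibition at the concentration tested (going by the name of the read-out), a lower number less inhibition. Compound 1 `Cc1ccc(S(=O)(=O)N(Cc2cn(Cc3ccc(F)cc3)nn2)Cc2c(-c3ccccc3)c3ccccc3n2S(=O)(=O)c2ccc(C)cc2)cc1` gives -7.6% in this assay. Compound 2 `Cc1ccc(S(=O)(=O)N(Cc2cn(Cc3ccccc3Cl)nn2)Cc2cn(S(=O)(=O)c3ccc(C)cc3)c3ccccc23)cc1` gives -4.8% in this assay, the highest of the three numbers, though its difference from compound 1 lies within the scatter; only its difference from compound 3 is beyond the scatter. Compound 3 `Cc1ccc(S(=O)(=O)n2cc(CN(Cc3cn(Cc4ccc(F)cc4)nn3)S(C)(=O)=O)c3ccccc32)cc1` gives -19.5% in this assay. None of the three shows inhibition at the tested concentration.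

Compound 4 `Cc1ccc(S(=O)(=O)N(Cc2cn(Cc3ccc(F)cc3F)nn2)Cc2cn(S(=O)(=O)c3ccc(C)cc3)c3ccccc23)cc1` is not yet measured. It differs from compound 2 by 2,4-difluorophenyl in place of 2-chlorophenyl on a saturated chain carbon bound to an aromatic nitrogen. Within the data shown here, no single-change step between measured compounds exists to calibrate this swap, so the expectation rests on the flat picture across compounds 1, 2 and 3. Because compound 2 sits at -4.8% and the other halogenated variants give no inhibition either, the step from compound 2 to compound 4 is expected to be a number 1.2 percentage points lower from compound 2 to compound 4 (within the scatter) in this assay, not beyond the scatter. Compound 4 is thus estimated at -6%, within -20% to 8%.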

Compound 4, a percentage reported as inhibition, at one concentration (the size of the read-out at that concentration, not a potency): 12.3%
Compound 4: the middle estimate sits 18.3 percentage points below what was measured; the measured number lies above the stated range.
By their numbers in this assay, from the lowest: compound 3; then compounds 1 and 2 (each within the scatter of the next); then compound 4.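

In this assay the swap to 2,4-difluorophenyl on a saturated chain carbon bound to an aromatic nitrogen gives a number 17.1 percentage points higher from compound 2 to compound 4 (beyond the scatter) on an otherwise unchanged structure, so this position does respond to the benzyl substitution. Among these compounds, the flat numbers of the earlier compounds could not show this, as no two of them differ in one place only. Nothing measured here bears on the reason for the step.

Among the compounds shown here, still open is whether the step comes from losing the chlorine or from gaining the two fluorines, as the single swap changes both at once. A plain benzyl on the same core would help separate the two, and a methoxy group or an amine on the benzyl ring would show whether the response extends beyond halogens.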